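A Weak Inhibitor and One Rearranged Group

The source may hold more compounds than are shown below. What is called first, only, known or untested is meant among the compounds shown, and "the series" means these compounds.

In a functional assay on PC-3 cells (Homo sapiens) for inhibition (a lower number here means a stronger inhibitor, a higher number a weaker inhibitor), compound 1 (`CN(O)C(=O)C/C=C/C=C/c1ccccc1`) gives 5370000 nM and compound 2 (`CN(O)C(=O)/C=C/C=C/c1ccccc1`) gives 11800000 nM as its reading. Compound 2 therefore has the higher of the two numbers, which makes it the weaker inhibitor of the pair, and the gap between them lies beyond the usual scatter. The next compound to be tested is compound 3 (`O=C(C/C=C/C=C/c1ccccc1)NO`), which has the same atoms as compound 2, joined differently. The change ((hydroxycarbamoyl)methyl in place of hydroxy(methyl)carbamoyl on a double-bonded chain carbon bound to a double-bonded chain carbon) puts (hydroxycarbamoyl)methyl in place of hydroxy(methyl)carbamoyl on a double-bonded chain carbon bound to a double-bonded chain carbon. Going by the values given here, with so few data, only a modest move towards stronger inhibition is expected, in line with compound 1 at 5370000 nM as the one lower reading available. The expected change is a 4.7-fold lower number from compound 2 to compound 3 (0.67 log units; beyond the scatter) in this assay and would lie beyond the scatter. Compound 3 is estimated at 2500000 nM (expected range 500000 nM to 9000000 nM).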

Compound 3, half-maximal inhibitory concentration: 44400000 nM
The estimate for compound 3 lay 18-fold (1.25 log units) below the measured number, and the stated range ends below it.
By their numbers in this assay, from the lowest: compound 1; then compound 2; then compound 3.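

In this assay, the rearrangement that turns hydroxy(methyl)carbamoyl into (hydroxycarbamoyl)methyl on a double-bonded chain carbon bound to a double-bonded chain carbon gives a 3.8-fold higher number from compound 2 to compound 3 (0.58 log units; beyond the scatter), so this change weakens inhibition rather than strengthening it. Removing only the methyl, with hydrogen in place of methyl on an amide-type nitrogen, gives an 8.3-fold higher number from compound 1 to compound 3 (0.92 log units; beyond the scatter), which shows that the methyl-bearing compound 1 is the stronger inhibitor of that pair, and compound 3 is the weakest of the three, since its steps to both others lie beyond the scatter. Nothing available here bears on the reason for either step.

As far as these compounds go, it remains open whether an ethyl group in place of that methyl would hold the reading of compound 1 or lose it. From the compounds shown here alone, it is equally open how a carboxylic acid in place of (hydroxycarbamoyl)methyl would compare with compound 3.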